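The source may hold more compounds than are shown below. What is called first, only, known or untested is meant among the compounds shown, and "the series" means these compounds.

Measured compounds:
- compound 1 `C#Cc1cn([C@@H]2O[C@H](CO)[C@@H](O)[C@H]2O)c2nc(C)nc(N)c12` — > 100000 nM
- compound 2 `Cc1nc(N)c2c(-c3ccsc3)cn([C@@H]3O[C@H](CO)[C@@H](O)[C@H]3O)c2n1` — > 100000 nM
- compound 3 `C#Cc1cn([C@@H]2O[C@H](CO)[C@@H](O)[C@H]2O)c2ncnc(SC)c12` — > 100000 nM

These three nucleoside-like compounds were tested in an ADME assay on MRC5 cells (Homo sapiens), read by MTT assay, with a stated time of 72 h; a lower number here means a stronger inhibitor, a higher number a weaker inhibitor. For compound 1 the value is only a limit of the assay, not a number. The same holds for compound 2, whose value is likewise a limit. For compound 3 the value is again a limit. Because all three sit at the limit of > 100000 nM in this assay, at which 3 of the 3 values shown sit, the change thiophen-3-yl in place of ethynyl on an aromatic carbon gives a step that the two limits leave unreadable from compound 1 to compound 2.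

Compound 4 `CSc1ncnc2c1c(-c1ccsc1)cn2[C@@H]1O[C@H](CO)[C@@H](O)[C@H]1O` has not yet been measured. It differs from compound 3 by thiophen-3-yl in place of ethynyl on an aromatic carbon, the same change that led from compound 1 to compound 2. The difference between the two cores is not broken down here. Since compound 3 gives only a limit, the step is expected to be a step that the limit leaves unreadable from compound 3 to compound 4, and compound 4 is expected to give about 150000 nM, most likely again only a limit in this assay.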

Compound 4, half-maximal inhibitory concentration: > 100000 nM
Compound 4 gave a limit, no number; the forecaster's own chance of this, stated with the estimate: 85%; the middle value is on the limit's open side.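

Compound 3 and compound 4 each give only a limit, not a number, so no step between them can be read: the limit of > 100000 nM in this assay, at which 4 of the 4 values shown sit.

The compounds shown leave open whether thiophen-3-yl in place of ethynyl changes inhibition at all.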